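This account rests on a few compounds, and the source may have more. Where it says the series, first, only, none or still open, it means among the compounds named here.

The measured compounds:

compound 1, `CSc1ccc(CNc2nc(SC)nc3ncccc23)cc1`: 7030 nM
compound 2, `COc1ccc(CNc2nc(SC)nc3ncccc23)cc1`: > 100000 nM
compound 3, `[SeH]c1nc(NCc2ccccc2)c2ccccc2n1`: > 100000 nM

In a functional assay on HT-29 cells (Homo sapiens) for cytotoxicity, read by MTT assay, with a stated time of 72 h (a higher number here means a weaker inhibitor of growth, a lower number a stronger inhibitor of growth), compound 1 gives 7030 nM. For compound 2 the value > 100000 nM is a limit of the assay and not a number. For compound 3 the value > 100000 nM is likewise a limit. Compound 2 therefore stands at the limit of > 100000 nM in this assay, at which 2 of the 3 values shown sit, with no measured number of its own. The one step that reaches it, an at least 14-fold higher number from compound 1 to compound 2 (1.15 log units; beyond the scatter), is the only measured step among these compounds.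

Compound 4, `CSc1nc(NCc2ccccc2)c2cccnc2n1`, differs from compound 2 by hydrogen in place of methoxy on an aromatic carbon. For the measured compounds named here, no measured step covers this exchange, and the step that does touch the same position, an at least 14-fold higher number from compound 1 to compound 2 (1.15 log units; beyond the scatter), runs between two different groups and ends at a limit, so it gives no direction for removing the methoxy group. The expected step in this assay is an at least 2.0-fold lower number from compound 2 to compound 4 (0.30 log units; that floor lies within the scatter), carrying wide uncertainty. Compound 4 is estimated at 50000 nM, with a range from 5000 nM to 200000 nM.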

Compound 4, concentration for total growth inhibition: > 100000 nM
Compound 4 gave a limit, no number (the forecaster's own chance of this, stated with the estimate: 50%); middle value at least 2.0-fold (0.30 log units) from the limit.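

In this assay compound 4 gives > 100000 nM, which is a limit of the assay and not a number. The step between compound 2 and compound 4 cannot be read, as both values are limits. Hydrogen in place of methylsulfanyl gives an at least 14-fold higher number from compound 1 to compound 4 (1.15 log units; beyond the scatter), so compound 1 now stands apart from two different replacements at this position, and of the compounds with this core only the one carrying methylsulfanyl gives a number: the limit of > 100000 nM in this assay, at which 3 of the 4 values shown sit.

As far as these compounds go, how far apart compound 2 and compound 4 lie stays unknown, and so does what sets methylsulfanyl apart from methoxy and hydrogen here. From the compounds shown here alone, whether another group at this place, such as an amine, a chlorine atom or the longer ethylsulfanyl chain, would give a number also remains open.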